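What a methoxy group might do to compound 1

This account rests on a few compounds, and the source may have more. Where it says the series, first, only, none or still open, it means among the compounds named here.

In a functional assay on HL-60 cells (Homo sapiens) for cytotoxicity, read by WST assay, with a stated time of 48 h (a higher number here means that more compound is needed for the effect, a lower number that less compound is needed), compound 1 `O=C1OC[C@H](Cc2ccccc2)[C@H]1Cc1ccccc1` gives 77000 nM. Compound 2 `O=C1OC[C@H](Cc2ccccc2)[C@H]1Cc1ccccc1O` gives 83000 nM, which is level with compound 1 within the scatter. Compound 3 `O=C1OC[C@H](Cc2ccccc2)[C@H]1Cc1cccc(C(F)(F)F)c1` gives 34000 nM, so compound 1 sits with compound 2 at the higher end of these three numbers, and compound 3 needs less compound for the effect.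

Compound 4 `COc1ccc(C[C@H]2C(=O)OC[C@@H]2Cc2ccccc2)cc1` keeps the core of compound 1 and changes one place: methoxy in place of hydrogen on an aromatic carbon. This is methoxy in place of hydrogen on an aromatic carbon, para to a large group.

Two measured steps of the same kind bear on this change. Hydroxy in place of hydrogen gave a 1.1-fold higher number from compound 1 to compound 2 (0.03 log units; within the scatter). Trifluoromethyl in place of hydrogen gave a 2.3-fold lower number from compound 1 to compound 3 (0.36 log units; beyond the scatter). Neither step is large, and neither involves methoxy, so only a small change is expected here, with a slight lean towards a lower number. The expected step is a 1.2-fold lower number from compound 1 to compound 4 (0.07 log units; within the scatter). For compound 4 the estimated value is 65000 nM, with an expected range from 30000 nM to 120000 nM.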

Compound 4, half-maximal effective concentration: 67000 nM
For compound 4 the middle estimate is 1.0-fold (0.01 log units) below the measured one, and the stated range covers the measured number.
By their numbers in this assay, from the lowest: compounds 3, 4, 1 and 2 (each within the scatter of the next, the first and the last beyond it).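

Methoxy on an aromatic carbon, para to a large group, gives a 1.1-fold lower number from compound 1 to compound 4 (0.06 log units; within the scatter) in this assay. So this place on the ring takes a group of 2 heavy atoms with 1 hydrogen-bond acceptor, and the number does not move beyond the usual scatter. This is the second change from compound 1 that stays within the scatter, alongside a 1.1-fold higher number from compound 1 to compound 2 (0.03 log units; within the scatter), while only a 2.3-fold lower number from compound 1 to compound 3 (0.36 log units; beyond the scatter) goes beyond it, and no measurement shown explains why the result for methoxy came out as it did.

An amine or a carboxylic acid in this same place, or a longer chain such as ethoxy, could show whether any group here moves the number beyond the scatter. As far as these compounds go, whether trifluoromethyl would give the same step in this place also remains open.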